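The source may hold more compounds than are shown below. What is called first, only, known or untested is meant among the compounds shown, and "the series" means these compounds.

Among the measured compounds shown here, compound 1 `CCCCCCCCCCCCCCCCCC(=O)Nc1nnc(S[C@@H]2O[C@H](COC(C)=O)[C@H](OC(C)=O)[C@H](OC(C)=O)[C@H]2OC(C)=O)s1` is the only compound here with a number: in an ADME assay on CHO-K1 cells (Cricetulus griseus) for cytotoxicity, read by MTT assay, with a stated time of 24 h (a lower number here means a stronger inhibitor, a higher number a weaker inhibitor), compound 1 gives 44700 nM. Compound 2 `CCCCCC(=O)Nc1nnc(S[C@@H]2O[C@H](CO)[C@H](O)[C@H](O)[C@H]2O)s1` is reported in this assay as "not active" (no number reported), without a number. Compound 3 `C=CCCCCCCCCC(=O)Nc1nnc(S[C@@H]2O[C@H](COC(C)=O)[C@H](OC(C)=O)[C@H](OC(C)=O)[C@H]2OC(C)=O)s1` is the compound still to be measured; it differs from compound 1 in one place: vinyl in place of nonyl on a saturated chain carbon, eight bonds along the chain from a carbonyl carbon. For the measured compounds named here, no measured pair shows a change of this kind, so the expectation rests on compound 1 alone. The expected step is a 1.7-fold higher number from compound 1 to compound 3 (0.22 log units; within the scatter), a modest weakening that reaches beyond the usual scatter. Compound 3 is therefore estimated at 75000 nM, within a range from 25000 nM to 220000 nM.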

Compound 3, half-maximal inhibitory concentration: 16300 nM
The estimate for compound 3 lay 4.6-fold (0.66 log units) above the measured number; measured number outside the range, below it.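

In this assay, vinyl in place of nonyl on a saturated chain carbon, eight bonds along the chain from a carbonyl carbon, gives a 2.7-fold lower number from compound 1 to compound 3 (0.44 log units; beyond the scatter) and shows that the number responds to a change at this position. This single step shortens the chain and adds a double bond together, so it cannot separate those two changes. Nothing available explains the shift. Still open, from the compounds shown here alone, is whether a saturated chain of the same length would match compound 3, and whether an amine or a carboxylic acid at the chain end would move the number further.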